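The source may hold more compounds than are shown below. What is called first, only, known or untested is meant among the compounds shown, and "the series" means these compounds.

Measured compounds:
Compound 1 `O=C1Nc2ccccc2/C1=N/NC(=S)N1CCN(C(=O)NO)CC1`: > 100000 nM (a limit of the assay)
Compound 2 `O=C(NO)N1CCN(C(=S)N/N=C/c2ccccc2Cl)CC1`: 13500 nM

Both compounds were tested in a functional assay on U-251 cells (Homo sapiens) for cytotoxicity, read by MTT assay, with a stated time of 48 h; on this read-out lower numbers stand for stronger inhibition of growth and higher numbers for weaker inhibition of growth. The entry for compound 1, > 100000 nM, is a limit and not a number. Within the data shown here, compound 2, at 13500 nM, holds the only actual number so far, and no step between measured compounds is available.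

Compound 3 `O=C(NO)N1CCN(C(=S)N/N=C/c2ccc(Cl)cc2)CC1` has not yet been measured. It carries 4-chlorophenyl in place of 2-chlorophenyl on a carbon with a double bond to nitrogen. The two have the same atoms, joined differently. With only compound 2 at 13500 nM as a guide, no change beyond the scatter is expected in this assay, in either direction. The expected change is a 1.0-fold higher number from compound 2 to compound 3 (0.02 log units; within the scatter). The estimated value for compound 3 is 14000 nM, with an expected range of 5000 nM to 40000 nM.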

Compound 3, concentration for 50% growth inhibition: 8500 nM
Estimate against measurement, compound 3: 1.6-fold (0.22 log units) above; the range from low to high includes it.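

In this assay, 4-chlorophenyl in place of 2-chlorophenyl on a carbon with a double bond to nitrogen gives a 1.6-fold lower number from compound 2 to compound 3 (0.20 log units; within the scatter). Among these compounds, this is the first step between measured compounds that can be read, and it shows that this exchange of two groups with the same atoms does not separate compound 2 from compound 3 beyond the usual scatter. Nothing shown accounts for the size of this step.

The compounds shown leave open whether a group of another kind at this place, such as an amine or a carboxylic acid on the phenyl ring, would move the number in this assay beyond the scatter. They also leave open whether an unsubstituted phenyl would give a value close to those of compound 2 and compound 3.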